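Adding a third methoxy to a quinoxaline sulfone series

The source may report more compounds than this note shows. Statements on the series, on what has been measured and on what is new or still open speak of the compounds shown alone.

Measured so far:
compound 1 `COc1cc(Nc2nc3ccccc3nc2S(=O)(=O)c2ccccc2)cc(OC)c1OC` — 29100 nM
compound 2 `COc1cc(Nc2nc3ccccc3nc2S(=O)(=O)c2ccc(C)cc2)cc(OC)c1OC` — 4850 nM
compound 3 `COc1ccc(S(=O)(=O)c2nc3ccccc3nc2Nc2cc(OC)cc(OC)c2)cc1` — 6220 nM

All three compounds were tested in a functional assay on PC-3 cells (Homo sapiens) for cytotoxicity, read by MTT assay, with a stated time of 72 h; on this read-out lower numbers stand for stronger inhibition and higher numbers for weaker inhibition. Compound 3 stands second highest of the three numbers: it sits nearest compound 2, and the two are within the scatter of each other, while compound 1 gives a number well above it. Among the measured compounds shown here, the only step between two compounds that differ in a single place is a 6.0-fold lower number from compound 1 to compound 2 (0.78 log units; beyond the scatter), a methyl entering on the ring attached to the sulfone.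

Compound 4 `COc1ccc(S(=O)(=O)c2nc3ccccc3nc2Nc2cc(OC)c(OC)c(OC)c2)cc1` differs from compound 3 by methoxy in place of hydrogen on an aromatic carbon. Compound 4 thus carries the same trimethoxy pattern as compound 1 and compound 2, with the methoxy-bearing sulfone ring of compound 3. For the measured compounds named here, no measured step tells what a third methoxy does on this ring, and the one known step concerns a different part of the molecule, so it gives no direct guidance. Compound 4 is therefore expected to stay close to the values of compound 2 and compound 3, with a step of a 1.2-fold lower number from compound 3 to compound 4 (0.09 log units; within the scatter) that may not exceed the scatter. The estimate for compound 4 in this assay is 5000 nM, with a range from 1500 nM to 16000 nM.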

Compound 4, half-maximal inhibitory concentration: 7850 nM
Compound 4: the middle estimate sits 1.6-fold (0.20 log units) below what was measured; measured number inside the range.
By their numbers in this assay, from the lowest: compounds 2, 3 and 4 (each within the scatter of the next); then compound 1.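

In this assay, methoxy in place of hydrogen on an aromatic carbon, ortho to two methoxy groups and para to a large group, gives a step that stays within the usual scatter (a 1.3-fold higher number from compound 3 to compound 4 (0.10 log units; within the scatter)), so at this position the added methoxy brings no change that can be told from noise. Methoxy in place of methyl likewise stays within the scatter (a 1.6-fold higher number from compound 2 to compound 4 (0.21 log units; within the scatter)), so these two groups cannot be told apart here, while methoxy in place of the hydrogen carried by compound 1 gives a modest step beyond it (a 3.7-fold lower number from compound 1 to compound 4 (0.57 log units; beyond the scatter)), which shows that a methyl is not the only group that separates a compound from compound 1. No available evidence bears on why these steps have the sizes they do.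

On these data alone, what remains open is whether a group of a different kind, such as an amine or a carboxylic acid, on the same aromatic carbon as the new methoxy would give a step beyond the scatter. It is also unknown whether a longer chain, such as butoxy, in place of the methoxy that sets compound 4 apart from compound 1 would keep, extend or lose the step seen there.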